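The source may hold more compounds than are shown below. What is called first, only, known or untested is meant among the compounds shown, and "the series" means these compounds.

Among the compounds with values here, in an ADME assay on liver for metabolic stability, with Liver microsome (Homo sapiens) as the target, read by LC-MS, using microsomes (on this read-out lower numbers stand for slow clearance and higher numbers for fast clearance), compound 3 `O=C(NCc1cc(Cl)ccc1-n1cnnn1)[C@@H]1CC=NN1C(=O)[C@H](O)c1ccccc1F` gives 16 mL.min-1.g-1, the only actual number among the readings so far. Compound 1 `O=C(NCc1cc(Cl)ccc1-n1cnnn1)[C@@H]1C[C@@H]2C[C@@H]2N1C(=O)[C@H](O)CC1CC1` reads < 12 mL.min-1.g-1, which is a limit of the assay. Compound 2 `O=C(NCc1cc(Cl)ccc1-n1cnnn1)[C@@H]1C[C@@H]2C[C@@H]2N1C(=O)[C@H](O)Cn1cccn1` reads < 12 mL.min-1.g-1, again a limit. Those two readings share (the limit of < 12 mL.min-1.g-1 in this assay, at which 2 of the 3 values shown sit).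

Compound 4 `CC(C)(C)C[C@@H](O)C(=O)N1N=CC[C@H]1C(=O)NCc1cc(Cl)ccc1-n1cnnn1` departs from compound 3 at one place, with neopentyl in place of 2-fluorophenyl on a saturated chain carbon bound to a carbonyl carbon and an oxygen on a saturated carbon.

Within the data shown here, the only measured step is a step that the two limits leave unreadable from compound 1 to compound 2, also an exchange of one group on a saturated chain carbon, and it offers no size to carry over. With compound 3 at 16 mL.min-1.g-1 as the sole numerical anchor, no step beyond the scatter is expected in this assay, and no direction can be argued from the data. The estimated step is a 1.1-fold higher number from compound 3 to compound 4 (0.05 log units; within the scatter). A reading at the limit remains possible. For compound 4 the expected value is 18 mL.min-1.g-1, within an estimated range of 9 mL.min-1.g-1 to 36 mL.min-1.g-1.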

Compound 4, intrinsic clearance in microsomes: 22 mL.min-1.g-1
Compound 4: middle estimate off by 1.2-fold (0.09 log units), on the low side, and the stated range covers the measured number.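

In this assay, this position, a saturated chain carbon bound to a carbonyl carbon and an oxygen on a saturated carbon, now has its first readable step: a 1.4-fold higher number from compound 3 to compound 4 (0.14 log units; within the scatter), with neopentyl in place of 2-fluorophenyl. Here, then, a group with no ring and no fluorine takes the place of a six-membered aromatic ring, and the read-out stays within the scatter. Compound 1 and compound 2 both read as a limit, so the only earlier step, also made on a saturated chain carbon, cannot be read: the limit of < 12 mL.min-1.g-1 in this assay, at which 2 of the 4 values shown sit.

From the compounds shown here alone, whether an amine or a carboxylic acid on this carbon would move the number beyond the scatter stays open. Equally open, going by these compounds, is how the cyclopropyl and 1H-pyrazol-1-yl groups would read on the core shared by compound 3 and compound 4.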